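Methoxy for Methyl in a Cytotoxicity Series

The source may report more compounds than this note shows. Statements on the series, on what has been measured and on what is new or still open speak of the compounds shown alone.

Compound 1 `Cc1ccc(-c2cc(/N=C3/NC(=O)CS3)cs2)cc1` serves as the starting point. In a functional assay on MDA-MB-231 cells (Homo sapiens) for cytotoxicity, read by MTT assay, with a stated time of 72 h (on this read-out higher numbers stand for weaker inhibition and lower numbers for stronger inhibition), compound 1 gives > 50000 nM, which is a limit of the assay rather than a number. Compound 2 `COc1ccc(-c2cc(/N=C3/NC(=O)CS3)cs2)cc1` carries methoxy in place of methyl on an aromatic carbon. In this assay compound 2 gives > 50000 nM, again a limit. The step that the two limits leave unreadable from compound 1 to compound 2 therefore cannot be sized. Compound 3 `COc1cccc(N2C(=O)CS/C2=N\c2csc(-c3ccc(C)cc3)c2)c1` differs from compound 1 by 3-methoxyphenyl in place of hydrogen on an amide-type nitrogen in a ring. In this assay compound 3 gives > 50000 nM, also a limit, so a step that the two limits leave unreadable from compound 1 to compound 3 is likewise unreadable. Compound 4 `COc1ccc(-c2cc(/N=C3\SCC(=O)N3c3cccc(OC)c3)cs2)cc1` repeats the same change, (methoxy in place of methyl on an aromatic carbon), this time on the core of compound 3. Since all three measured values sit at the limit of > 50000 nM in this assay, at which 3 of the 3 values shown sit, the step from compound 3 to compound 4 is expected to remain unreadable as well, a step that the limit leaves unreadable from compound 3 to compound 4, matching a step that the two limits leave unreadable from compound 1 to compound 2. Compound 4 is accordingly estimated at 80000 nM in this assay.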

Compound 4, half-maximal inhibitory concentration: 2700 nM
For compound 4 the middle estimate is 30-fold (1.47 log units) above the measured one; measured number below the stated range.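

In this assay, methoxy in place of methyl gives an at least 18-fold lower number from compound 3 to compound 4 (1.26 log units; beyond the scatter), and 3-methoxyphenyl in place of hydrogen on the amide-type nitrogen in a ring gives an at least 18-fold lower number from compound 2 to compound 4 (1.26 log units; beyond the scatter), so among the compounds shown, only the one carrying both groups shows a readable result. This shows that the methoxy change can matter greatly on one core, but it does not show that the change carries over from one core to another. All other steps cannot be read, including the same change on the core of compound 1: the limit of > 50000 nM in this assay, at which 3 of the 4 values shown sit.

The compounds shown leave open what an amine, a carboxylic acid or a longer chain such as ethoxy would give in place of that methoxy. They also leave open what a benzyl group would give in place of the 3-methoxyphenyl.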